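Methoxy to bromo swap carried from one core to another

The compounds below may be only part of what the source reports. "The series", "measured", "known", "first", "only" and "open" are said of these compounds alone.

Compound 1 `CCOC(=O)c1csc2nc(CN3CCN(Cc4ccccc4)CC3)c(-c3ccc(OC)cc3)n12` and compound 2 `CCOC(=O)c1csc2nc(CN3CCN(Cc4ccccc4)CC3)c(-c3ccc(Br)cc3)n12` share one core and differ in a single place: bromo in place of methoxy on an aromatic carbon. In a functional assay on PC-3 cells (Homo sapiens) for antiproliferative activity, read by MTT assay, with a stated time of 72 h (on this read-out lower numbers stand for stronger inhibition and higher numbers for weaker inhibition), compound 1 gives 29400 nM, and compound 2 gives 56400 nM; the measured step is a 1.9-fold higher number from compound 1 to compound 2 (0.28 log units; within the scatter), so the swap leaves the read-out essentially unchanged within this pair.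

Compound 3 `COc1ccc(-c2c(CN3CCCCC3)nc3scc(C(=O)O)n23)cc1` is built on a second core; the difference between the two cores is not broken down here. In this assay compound 3 gives 73100 nM. Its number and that of compound 2 lie within the scatter of each other, while the gap to compound 1 lies beyond it.

Compound 4 `O=C(O)c1csc2nc(CN3CCCCC3)c(-c3ccc(Br)cc3)n12` is the unmeasured partner of compound 3, and the two differ in one place: bromo in place of methoxy on an aromatic carbon. The place description matches that of the first pair word for word, so this is the same change, and it occurs twice among the compounds shown. For compound 4 the expected step is a 1.6-fold higher number from compound 3 to compound 4 (0.22 log units; within the scatter). Among the compounds with values here, that expectation rests on the single measured instance, a 1.9-fold higher number from compound 1 to compound 2 (0.28 log units; within the scatter), transferred to a different core, which widens the uncertainty; no second example on either core is available. Compound 4 is estimated at 120000 nM, with a range from 50000 nM to 300000 nM, and a number this far out may fall beyond what the read-out resolves.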

Compound 4, half-maximal inhibitory concentration: > 100000 nM
Compound 4: no number, only a limit; the forecaster's own chance of this, stated with the estimate: 25%; the middle value is on the limit's open side.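

In this assay compound 4 gives > 100000 nM, which is a limit of the assay and not a number. Read against that limit, the change from 4-methoxyphenyl to 4-bromophenyl gives an at least 1.3-fold higher number from compound 3 to compound 4 (0.13 log units; that floor lies within the scatter), so the core of compound 3 yields only a floor and no size for the step. The two cores therefore show no separation, but the data also do not show that the change carries over with the same size: the same change on two cores in this assay, a 1.9-fold higher number (0.28 log units; within the scatter) from compound 1 to compound 2 and an at least 1.3-fold higher number (0.13 log units; that floor lies within the scatter) from compound 3 to compound 4; the limit leaves it open whether they differ

Within the data shown here, still open is how the step on the core of compound 3 would compare with that on the core of compound 1 if compound 4 had a number in place of a limit, with only one pair on each core to go on. Also open, as far as these compounds go, is how chloro or trifluoromethyl on the same aromatic carbon would read on either core, and whether an amide in place of the carboxylic acid of compound 3 would give values clear of the limit.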